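Methoxy to Chloro: a Drop in Growth Inhibition Expected

A few compounds are considered here, and "the series" means these few. Any claim that something is new, unique, unknown or untested is made for them only; others in the source may bear on it.

In a functional assay on A549 cells (Homo sapiens) for inhibition, read by sulforhodamine B assay, tested at 10 uM (on this read-out lower numbers stand for less inhibition of growth and higher numbers for more inhibition of growth at the one concentration tested), compound 2 `COc1ccc(C2=NN(C(C)=O)C(c3ccc(OCc4cn(Cc5ccc([N+](=O)[O-])cc5)nn4)c(OC)c3)C2)cc1` gives 43%, the higher of the two numbers measured. Compound 1 `COc1cc(C2CC(c3ccc(Br)cc3)=NN2C(C)=O)ccc1OCc1cn(Cc2ccc([N+](=O)[O-])cc2)nn1` gives 0% in this assay. Compound 3 `COc1cc(C2CC(c3ccc(Cl)cc3)=NN2C(C)=O)ccc1OCc1cn(Cc2ccc([N+](=O)[O-])cc2)nn1` differs from compound 2 by chloro in place of methoxy on an aromatic carbon. For the measured compounds named here, the one measured step that bears on this change, a number 43 percentage points higher from compound 1 to compound 2 (beyond the scatter), runs the other way, with bromo rather than chloro as the halogen. A step of comparable size back down is therefore expected in this assay, roughly a number 33 percentage points lower from compound 2 to compound 3 (beyond the scatter). Compound 3 is estimated at 10%, within 0% to 30%.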

Compound 3, percent growth inhibition at one concentration: 0%
Beside the measured number, compound 3's estimate is 10 percentage points above it; the measured number falls inside the stated range.
By their numbers in this assay, from the lowest: compounds 1 and 3 (each within the scatter of the next); then compound 2.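

In this assay, the change from 4-methoxyphenyl to 4-chlorophenyl gives a number 43 percentage points lower from compound 2 to compound 3 (beyond the scatter) and so shows that the loss seen with bromo also occurs with a second halogen. The two halogens cannot be told apart here, with no change at the digits printed from compound 1 to compound 3 (within the scatter) in this comparison, and of the three groups at this position only methoxy stands beyond the scatter from the others. From the compounds shown here alone, whether this belongs to methoxy itself stays open, as a hydroxy, an ethoxy or an amine at the same place could show. Nothing measured here gives a reason for the difference.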